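The compounds below may be only part of what the source reports. "The series", "measured", "known", "first", "only" and "open" are said of these compounds alone.

Compound 1, `CCC1C(=O)N(C)c2cnc(Nc3ccc(S(=O)(=O)NC)cc3)nc2N1c1ccn(C)n1`: 71.6 nM
Compound 2, `CC[C@@H]1C(=O)N(C)c2cnc(Nc3ccc(S(=O)(=O)NC)cc3)nc2N1C1CCCC1`: 3.4 nM
Compound 3, `CC[C@@H]1C(=O)N(C)c2cnc(-n3ccc4ccccc43)nc2N1C1CCCC1`: 355 nM

These three numbers all come from an assay for inhibition of serine/threonine-protein kinase PLK2 (Homo sapiens), read by FRET and Z'-LYTE, with a stated time of 1 h; on this read-out higher numbers stand for weaker inhibition and lower numbers for stronger inhibition. Compound 2 stands lowest of the three. Compound 1 comes nearest to it, yet its number is clearly higher, beyond the scatter of repeated measurements; compound 3 lies furthest away, with a number higher still. Compound 2 is therefore the strongest inhibitor among the measured compounds.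

Compound 4, `CC[C@@H]1C(=O)N(C)c2cnc(Nc3ccc(S(N)(=O)=O)cc3)nc2N1C1CCCC1`, has not yet been measured. It differs from compound 2 in one place only: hydrogen in place of methyl on a sulfonamide nitrogen. For the measured compounds named here, no pair of measured compounds shows this same change, so there is no step of this kind to lean on. A change this small, confined to a single carbon on a sulfonamide nitrogen, is expected to move the number little, in either direction, and most likely not beyond the scatter. Compound 4 is therefore expected to give about 4.5 nM in this assay, with a range from 1.5 nM to 14 nM. That estimate amounts to a step of a 1.3-fold higher number from compound 2 to compound 4 (0.12 log units; within the scatter), expected to stay within the usual scatter.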

Compound 4, half-maximal inhibitory concentration: 10.2 nM
For compound 4 the middle estimate is 2.3-fold (0.36 log units) below the measured one, and the stated range covers the measured number.
By their numbers in this assay, from the lowest: compound 2; then compound 4; then compound 1; then compound 3.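

In this assay, the methyl on the sulfonamide nitrogen proves to matter: with hydrogen in its place there is a 3.0-fold higher number from compound 2 to compound 4 (0.48 log units; beyond the scatter), a modest step but one beyond the scatter. For the compounds shown here, no earlier pair isolated this position, so this is the first sign that a single carbon there can shift the number, with the methylsulfamoyl form giving stronger inhibition than the sulfamoyl form in this one pair. No measurement at hand explains the shift.

The compounds shown leave open whether a longer chain on this nitrogen, such as ethyl or propyl, would lower the number further or raise it again. They also leave open whether the same change from methyl to hydrogen would move the number as far on the core of compound 1.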